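The source may report more compounds than this note shows. Statements on the series, on what has been measured and on what is new or still open speak of the compounds shown alone.

Measured in a physicochemical assay for solubility, read by spectrophotometry, in phosphate buffer, with a stated time of 18 h, at pH 7.4; a lower number here means a less soluble compound, a higher number a more soluble compound:
- compound 1 `CCc1ccc(-c2nc3c(c(C)nn3-c3ccccc3)c(-c3ccccc3OC(F)(F)F)c2C#N)cc1`: 9900 nM
- compound 2 `Cc1cccc(-c2nc3c(c(C)nn3-c3ccccc3)c(-c3ccccc3O)c2C#N)c1`: 42000 nM
- compound 3 `Cc1ccccc1-c1nc2c(c(C)nn2-c2ccccc2)c(-c2ccccc2O)c1C#N`: 21000 nM

In this assay, compound 3 gives 21000 nM, within the scatter of compound 2. Compound 1 gives a lower number than either, and its gap to compound 3 lies beyond the scatter.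

The next compound is compound 4 `Cc1nn(-c2ccccc2)c2nc(-c3ccc(C(F)(F)F)cc3)c(C#N)c(-c3ccccc3O)c12`. The change is 4-(trifluoromethyl)phenyl in place of 2-methylphenyl on an aromatic carbon, next to the ring nitrogen and ortho to a cyano group.

Going by the values given here, only one measured step touches this place: a 2.0-fold lower number from compound 2 to compound 3 (0.30 log units; within the scatter). It swaps 3-methylphenyl for 2-methylphenyl and so says little about a 4-(trifluoromethyl)phenyl group. Among the compounds with values here, no measured pair tests that group directly. Within the data shown here, compound 1 is the only measured compound that carries fluorine, at 9900 nM, but it differs from compound 3 in more than one place, so it is weak guidance on direction.

On this thin evidence, the expected change is a 2.3-fold lower number from compound 3 to compound 4 (0.37 log units; beyond the scatter), a modest move towards a lower number. The estimate for compound 4 is 9000 nM, with an expected range of 3500 nM to 22000 nM.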

Compound 4, solubility: 3500 nM
Beside the measured number, compound 4's estimate is 2.6-fold (0.41 log units) above it; measured number inside the range.
By their numbers in this assay, from the lowest: compound 4; then compound 1; then compounds 3 and 2 (each within the scatter of the next).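

In this assay, this position, on an aromatic carbon next to the ring nitrogen and ortho to a cyano group, proves sensitive to the aryl group it carries: 4-(trifluoromethyl)phenyl in place of 2-methylphenyl gives a 6.0-fold lower number from compound 3 to compound 4 (0.78 log units; beyond the scatter). Going by these compounds alone, in place of 3-methylphenyl, the same group gives a 12-fold lower number from compound 2 to compound 4 (1.08 log units; beyond the scatter), whereas the only earlier step here, between the two methylphenyl groups, was a 2.0-fold lower number from compound 2 to compound 3 (0.30 log units; within the scatter). No measured property bearing on this change is available, so the data record the size and direction of these steps and offer no explanation for them.

Both new steps change the substituent on the phenyl group and its place on that ring together, so the compounds shown cannot separate the two. As far as these compounds go, it also remains open how a plain phenyl group would compare at this position, and whether an amine or a carboxylic acid on the phenyl group would give a higher number in this assay.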